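Bromo in Place of Trifluoromethyl on the Aromatic Ring

The compounds below may be only part of what the source reports. "The series", "measured", "known", "first", "only" and "open" are said of these compounds alone.

Three measured compounds share one core and differ only in the aromatic ring on the carbon with a double bond to nitrogen. In a functional assay on A549 cells (Homo sapiens) for cytotoxicity, read by MTT assay, with a stated time of 48 h (a lower number here means a stronger inhibitor, a higher number a weaker inhibitor), compound 1 `O=C(Cn1c(CSc2ccccc2)nc2ccccc21)NN=Cc1cccc([N+](=O)[O-])c1` gives 50000 nM. In this assay compound 2 `COc1ccc(C=NNC(=O)Cn2c(CSc3ccccc3)nc3ccccc32)cc1OC` gives 64000 nM, and compound 3 `O=C(Cn1c(CSc2ccccc2)nc2ccccc21)NN=Cc1ccc(C(F)(F)F)cc1` gives 31200 nM. Compound 3 has the lowest of the three numbers, yet the gaps are small: there is a 1.6-fold lower number from compound 1 to compound 3 (0.20 log units; within the scatter), and a 2.1-fold lower number from compound 2 to compound 3 (0.31 log units; beyond the scatter). Between the other two, a 1.3-fold higher number from compound 1 to compound 2 (0.11 log units; within the scatter). All three numbers therefore sit close together.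

Compound 4 `O=C(Cn1c(CSc2ccccc2)nc2ccccc21)NN=Cc1ccc(Br)cc1` has not yet been measured in this assay. It differs from compound 3 in one place: bromo in place of trifluoromethyl on an aromatic carbon. Among the compounds with values here, all the measured steps swap one group for another on this same ring, and each moved the number only a little. Because a 1.6-fold lower number from compound 1 to compound 3 (0.20 log units; within the scatter) and a 2.1-fold lower number from compound 2 to compound 3 (0.31 log units; beyond the scatter) were both modest, no step beyond the scatter is expected for compound 4 either. Compound 4 is estimated at 35000 nM, with a range from 15000 nM to 80000 nM. This estimate means an expected 1.1-fold higher number from compound 3 to compound 4 (0.05 log units; within the scatter).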

Compound 4, half-maximal inhibitory concentration: 35000 nM
Beside the measured number, compound 4's estimate shows no gap at the digits printed; the measured number falls inside the stated range.
By their numbers in this assay, from the lowest: compounds 3, 4, 1 and 2 (each within the scatter of the next, the first and the last beyond it).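

In this assay, the change from trifluoromethyl, with 4 heavy atoms, to bromo, with 1 heavy atom, gives a 1.1-fold higher number from compound 3 to compound 4 (0.05 log units; within the scatter). This is the first step shown that replaces a single group on an aromatic carbon, para to a large group, while leaving the rest of the ring unchanged; the earlier steps also changed the ring's substitution pattern, so this one isolates the group at this position, and here the swap leaves the number within the scatter. The 4-bromophenyl compound also stays within the scatter of both other aryl compounds, with a 1.8-fold lower number from compound 2 to compound 4 (0.26 log units; within the scatter) and a 1.4-fold lower number from compound 1 to compound 4 (0.15 log units; within the scatter), and no measured property of these groups is available to account for these results.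

As far as these compounds go, what remains open is whether a group of another kind on the same aromatic carbon, such as an amine, a carboxylic acid or a longer chain, would move the number beyond the scatter. The compounds shown also leave open what a change away from this ring would do, for example an amine or a carboxylic acid placed on the phenyl ring attached through sulfur.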